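The source may report more compounds than this note shows. Statements on the series, on what has been measured and on what is new or still open speak of the compounds shown alone.

Compound 1 `CCCCCN(Cc1ccc(C(=O)NO)cc1)c1ncc(-c2ccc(C)cc2)s1` and compound 2 `CCCCCCCCN(Cc1ccc(C(=O)NO)cc1)c1ncc(-c2ccc(C)cc2)s1` share one core and differ only in the length of the chain on the nitrogen. Among the measured compounds shown here, in a functional assay on PC-3 cells (Homo sapiens) for antiproliferative activity, read by MTT assay, with a stated time of 48 h (a higher number here means a weaker inhibitor of growth, a lower number a stronger inhibitor of growth), compound 1 gives 5060 nM, and compound 2 gives 13300 nM, which is the higher of the two numbers; the step of a 2.6-fold higher number from compound 1 to compound 2 (0.42 log units; beyond the scatter) is the only measured step available. Compound 3 `Cc1ccc(OCCCCN(Cc2ccc(C(=O)NO)cc2)c2ncc(-c3ccc(C)cc3)s2)cc1` is the next compound, and it differs from compound 2 by 4-methylphenoxy in place of butyl on a saturated chain carbon, four bonds along the chain from a nitrogen on an aromatic ring. For the measured compounds named here, the one measured step bears on it only loosely, since it lengthened the chain, while here a ring-bearing group replaces the end of the chain. With so little to go on, the estimate for compound 3 is kept close to the number for compound 2, with a small step of a 1.1-fold lower number from compound 2 to compound 3 (0.04 log units; within the scatter) expected in no firm direction. Compound 3 is therefore expected to give about 12000 nM in this assay, within a range of 4000 nM to 36000 nM.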

Compound 3, concentration for 50% growth inhibition: 1220 nM
Compound 3: the middle estimate sits 9.8-fold (0.99 log units) above what was measured; measured number outside the range, below it.
By their numbers in this assay, from the lowest: compound 3; then compound 1; then compound 2.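

In this assay the swap of butyl for 4-methylphenoxy gives an 11-fold lower number from compound 2 to compound 3 (1.04 log units; beyond the scatter) and the swap of methyl for the same group gives a 4.1-fold lower number from compound 1 to compound 3 (0.62 log units; beyond the scatter), so this place on the saturated chain tolerates a group carrying an aromatic ring and the number falls below those of both alkyl compounds. The earlier step showed only a rise on going from pentyl to octyl, and compound 3 goes against any reading that a larger group on the nitrogen raises the number. No measurement is available to explain this drop.

The compounds shown do not separate the part played by the ring from that of the ether oxygen or the ring methyl. As far as these compounds go, whether a plain phenoxy, a phenyl joined without oxygen, or an amine at the chain end would behave the same remains open.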